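The source may report more compounds than this note shows. Statements on the series, on what has been measured and on what is new or still open speak of the compounds shown alone.

Measured in a functional assay on MDA-MB-435 cells (Homo sapiens) for cytotoxicity, read by MTT assay, with a stated time of 72 h; on this read-out higher numbers stand for weaker inhibition and lower numbers for stronger inhibition:
- Compound 1 `CN(C)CCCNc1c(C(=O)NCc2ccc(F)cc2)nc(Br)c2cccnc12`: 7000 nM
- Compound 2 `O=C(NCc1ccc(F)cc1)c1nc(Br)c2cccnc2c1NCCO`: > 20000 nM (a limit of the assay, not a number)

Compound 2 stands at the limit of > 20000 nM in this assay, at which 1 of the 2 values shown sits. Compound 3 `O=C(NCCCNc1c(C(=O)NCc2ccc(F)cc2)nc(Br)c2cccnc12)c1ccccc1` differs from it as follows: benzamidomethyl in place of hydroxy on a saturated chain carbon, two bonds along the chain from a nitrogen on an aromatic ring. It carries benzamidomethyl in place of hydroxy on a saturated chain carbon, two bonds along the chain from a nitrogen on an aromatic ring. Among the compounds with values here, one measured step bears on this place: an at least 2.8-fold higher number from compound 1 to compound 2 (0.45 log units; beyond the scatter). Read in reverse, that step suggests a modest move to a lower number in this assay, although the entering group is a different one. The expected step is an at least 1.8-fold lower number from compound 2 to compound 3 (0.25 log units; that floor lies within the scatter). The estimate for compound 3 is 11000 nM, with an expected range of 4000 nM to 20000 nM.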

Compound 3, half-maximal inhibitory concentration: > 20000 nM
Compound 3: only a limit was reported; the forecaster's own chance of this, stated with the estimate: 40%; middle value at least 1.8-fold (0.25 log units) away from the limit.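

Replacing dimethylamino with benzamido on the saturated chain gives an at least 2.8-fold higher number from compound 1 to compound 3 (0.45 log units; beyond the scatter), so this second replacement, like hydroxy, does not keep the level of compound 1. For compound 3, > 20000 nM in this assay is a limit of the assay, not a number. The step between compound 2 and compound 3 cannot be read, and only compound 1 gives a number at this position: the limit of > 20000 nM in this assay, at which 2 of the 3 values shown sit.

As far as these compounds go, whether another amine, such as pyrrolidine or a primary amine, would hold or improve on compound 1 stays open. So does the effect of a carboxylic acid or a longer chain here.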